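Lengthening the chain: from compound 2 to compound 4

This account rests on a few compounds, and the source may have more. Where it says the series, first, only, none or still open, it means among the compounds named here.

Values in a functional assay on MGC-803 cells (Homo sapiens) for antiproliferative activity, read by MTT assay, with a stated time of 48 h; a higher number here means a weaker inhibitor, a lower number a stronger inhibitor:
- compound 1 `CCCCCCCn1cc(COC[C@@H]2OC[C@H](N)[C@@H]2O)nn1`: > 128000 nM (a limit)
- compound 2 `CCCCCCCCCn1cc(COC[C@@H]2OC[C@H](N)[C@@H]2O)nn1`: 13800 nM
- compound 3 `CCCCCCCCCCn1cc(COC[C@@H]2OC[C@H](N)[C@@H]2O)nn1`: 8780 nM

Compound 1 gives only a limit and no number. Among the measured compounds shown here, compound 2 stands within the scatter of compound 3, the only other compound with a number. Compound 4 `CCCCCCCCCCCCn1cc(COC[C@@H]2OC[C@H](N)[C@@H]2O)nn1` differs from compound 2 by propyl in place of hydrogen on a saturated chain carbon, nine bonds along the chain from an aromatic nitrogen. The closest guide is the methyl addition at the same place, a 1.6-fold lower number from compound 2 to compound 3 (0.20 log units; within the scatter). The steps of an at least 9.2-fold lower number from compound 1 to compound 2 (0.96 log units; beyond the scatter) and an at least 14-fold lower number from compound 1 to compound 3 (1.16 log units; beyond the scatter) are larger, but they begin further down the chain, at a saturated carbon seven bonds along from the aromatic nitrogen. A modest move to a lower number in this assay is therefore expected, close to the edge of the scatter. The expected step is a 2.5-fold lower number from compound 2 to compound 4 (0.40 log units; beyond the scatter). For compound 4 the estimated value is 5500 nM, with an expected range of 2000 nM to 15000 nM.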

Compound 4, half-maximal inhibitory concentration: 21400 nM
Estimate against measurement, compound 4: 3.9-fold (0.59 log units) below; measured number outside the range, above it.
By their numbers in this assay, from the lowest: compounds 3, 2 and 4 (each within the scatter of the next, the first and the last beyond it). At a limit, above all of these: compound 1.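

In this assay lengthening the chain stops paying at this position: the propyl change nine bonds along the chain gives a 1.6-fold higher number from compound 2 to compound 4 (0.19 log units; within the scatter), and the ethyl change gives a 2.4-fold higher number from compound 3 to compound 4 (0.39 log units; beyond the scatter). Among the compounds shown here, the step of an at least 5.9-fold lower number from compound 1 to compound 4 (0.77 log units; beyond the scatter) starts from a limit, the only reading for compound 1, and compound 4 stays clear of it. Added chain length therefore does not act alike on every chain: the same change on two cores in this assay, an at least 14-fold lower number (1.16 log units; beyond the scatter) from compound 1 to compound 3 and a 1.6-fold higher number (0.19 log units; within the scatter) from compound 2 to compound 4, at least 22-fold (1.35 log units) apart, beyond the scatter of two such steps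

Undecyl, which lies in length between the chains of compound 3 and compound 4, remains open, as does a longer chain than that of compound 4. From the compounds shown here alone, an amine or a carboxylic acid carried on the chain also remains open.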